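The source may hold more compounds than are shown below. What is called first, only, known or untested is meant among the compounds shown, and "the series" means these compounds.

Compound 1 `CC(C)=CCC/C(C)=C/CC/C(C)=C/C(=O)NC(=N)N`: 10000 nM
Compound 2 `CC(C)=CCC/C(C)=C/CC/C(C)=C/C(=O)NC(=N)NC(=O)/C=C(\C)CC/C=C(\C)CCC=C(C)C`: 6800 nM
Compound 3 `CC(C)=CCC/C(C)=C/C(=O)NC(=N)N`: 39400 nM

All three were tested in a functional assay on Hs 683 cells (Homo sapiens) for inhibition, read by MTT assay, with a stated time of 72 h; on this read-out higher numbers stand for weaker inhibition of growth and lower numbers for stronger inhibition of growth. Compound 2 differs from compound 1 in more than one place, and the difference between the two cores is not broken down here; their values lie close together. Compound 3 comes from compound 1 by a single change, (hydrogen in place of 3-methylbut-2-en-1-yl on a saturated chain carbon bound to a double-bonded chain carbon), and that change gave a 3.9-fold higher number from compound 1 to compound 3 (0.60 log units; beyond the scatter). Compound 4 `CC(C)=CCC/C(C)=C/CC/C(C)=C/C(=O)NC(=N)NC(=O)/C=C(\C)CCC=C(C)C` has not yet been measured. It comes from compound 2 by the same change, (hydrogen in place of 3-methylbut-2-en-1-yl on a saturated chain carbon bound to a double-bonded chain carbon), made at the same kind of place. Because the earlier step was a 3.9-fold higher number from compound 1 to compound 3 (0.60 log units; beyond the scatter), a step of similar size is expected here: a 3.7-fold higher number from compound 2 to compound 4 (0.57 log units; beyond the scatter). On that basis compound 4 is estimated at 25000 nM, most likely falling between 10000 nM and 60000 nM.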

Compound 4, concentration for 50% growth inhibition: 37400 nM
Estimate against measurement, compound 4: 1.5-fold (0.17 log units) below, within the range that was stated.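

Replacing the 3-methylbut-2-en-1-yl group with hydrogen also weakened growth inhibition in this assay on a second core, giving a 5.5-fold higher number from compound 2 to compound 4 (0.74 log units; beyond the scatter). The change carried over from one core to the other with a similar effect size: the same change on two cores in this assay, a 3.9-fold higher number (0.60 log units; beyond the scatter) from compound 1 to compound 3 and a 5.5-fold higher number (0.74 log units; beyond the scatter) from compound 2 to compound 4, 1.4-fold (0.14 log units) apart, within the scatter of two such steps. This rests on just two pairs in one cell line, so it shows that the step held on these two cores, not that it would hold on other cores or in other assays.

The compounds shown leave open what happens when the same change is made on both chains of a compound at once. They also leave open whether a longer chain, or a chain ending in an amine or a carboxylic acid, would inhibit growth more or less strongly.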